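This account rests on a few compounds, and the source may have more. Where it says the series, first, only, none or still open, it means among the compounds named here.

Compound 1 `CCc1c(F)c(N)c2c(=O)cc(-c3ccc(N)c(F)c3)oc2c1F`: 130 nM
Compound 2 `Nc1ccc(-c2cc(=O)c3c(N)c(F)c(O)c(F)c3o2)cc1F`: > 10000 nM

In a functional assay on MCF7 cells (Homo sapiens) for cytotoxicity, read by neutral red uptake, with a stated time of 3 days (on this read-out lower numbers stand for stronger inhibition and higher numbers for weaker inhibition), compound 1 gives 130 nM. Compound 2 reaches only > 10000 nM, which is a limit of the assay the limit of > 10000 nM in this assay, at which 1 of the 2 values shown sits, rather than a number. Compound 2 therefore stands at the weak end of the two values shown. Compound 3 `Nc1ccc(-c2cc(=O)c3c(N)c(F)c(N)c(F)c3o2)cc1F` differs from compound 2 by amino in place of hydroxy on an aromatic carbon. Within the data shown here, the single measured step, an at least 76-fold higher number from compound 1 to compound 2 (1.88 log units; beyond the scatter), concerns a different exchange, so no measured step covers amino in place of hydroxy here. Compound 3 is estimated at 10000 nM, within 2000 nM to 50000 nM, with the expected step of a number no higher from compound 2 to compound 3 (the limit leaves the size open) likely staying within the scatter.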

Compound 3, half-maximal inhibitory concentration: 7.7 nM
The estimate for compound 3 lay 1300-fold (3.11 log units) above the measured number, outside the stated range (below it).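

In this assay, amino in place of hydroxy on the aromatic carbon ortho to two fluoro groups gives an at least 1200-fold lower number from compound 2 to compound 3 (3.11 log units; beyond the scatter). The value of compound 2 is a limit and not a number: the limit of > 10000 nM in this assay, at which 1 of the 3 values shown sits. Amino in place of ethyl on the same carbon gives a 17-fold lower number from compound 1 to compound 3 (1.23 log units; beyond the scatter), so among the three groups shown, amino gives the lowest number at this position.

The compounds shown leave open whether a methylamino group, a methoxy group or a lone hydrogen at this carbon would keep the number this low. They also give no measured property that would explain the size of these steps.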